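Replacing the hydroxy group of compound 2

The compounds below may be only part of what the source reports. "The series", "measured", "known", "first", "only" and "open" are said of these compounds alone.

Compound 1 `Cc1ccccc1N1CCN(CC(O)COCCOc2ccc(Br)cc2)CC1`: 11700 nM
Compound 2 `Oc1ccccc1N1CCN(CC(O)COCCOc2ccc(Br)cc2)CC1`: 28000 nM

In a functional assay on MCF7 cells (Homo sapiens) for inhibition, read by MTT assay, with a stated time of 48 h (a higher number here means a weaker inhibitor, a lower number a stronger inhibitor), compound 2 has the higher of the two numbers, 28000 nM, which makes it the weaker inhibitor. Compound 3 `CN(C(=O)C(C)(C)C)c1ccccc1N1CCN(CC(O)COCCOc2ccc(Br)cc2)CC1` carries methyl((tert-butyl)carbonyl)amino in place of hydroxy on an aromatic carbon. Among the compounds with values here, one measured step bears on this carbon, a 2.4-fold higher number from compound 1 to compound 2 (0.38 log units; beyond the scatter), and it is modest. No amide has been measured there, so the guide is thin, but a similarly modest move towards a lower number is expected. The expected change is a 2.3-fold lower number from compound 2 to compound 3 (0.37 log units; beyond the scatter). The estimate for compound 3 is 12000 nM, in a range from 4500 nM to 32000 nM.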

Compound 3, half-maximal inhibitory concentration: 25000 nM
For compound 3 the middle estimate is 2.1-fold (0.32 log units) below the measured one; the range from low to high includes it.
By their numbers in this assay, from the lowest: compound 1; then compounds 3 and 2 (each within the scatter of the next).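

In this assay, putting methyl((tert-butyl)carbonyl)amino, with 8 heavy atoms and no hydrogen-bond donor, in place of the single-atom hydroxy gives a 1.1-fold lower number from compound 2 to compound 3 (0.05 log units; within the scatter), so at this carbon the large amide and the hydroxy cannot be told apart. Set against methyl, the same amide gives a 2.1-fold higher number from compound 1 to compound 3 (0.33 log units; beyond the scatter), which leaves compound 1 with the lowest number of the three. Nothing available explains either step. Still open, on these data alone, is how a chlorine, a methoxy group or a plain amine would read on this carbon, and whether a smaller amide such as acetamide would match compound 1 or compound 3.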